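From Nitro to Chloro at the Limit

The source may report more compounds than this note shows. Statements on the series, on what has been measured and on what is new or still open speak of the compounds shown alone.

In an ADME assay on J774 cells (Mus musculus) for cytotoxicity, read by fluorescence and resazurin assay, with a stated time of 24 h (on this read-out higher numbers stand for lower toxicity in this test and lower numbers for higher toxicity in this test), compound 1 (`O=[N+]([O-])c1ccc(S(=O)(=O)Nc2nccc3ccccc23)cc1`) gives 41300 nM. Compound 2 (`O=S(=O)(Nc1nccc2ccccc12)c1ccccc1`) reads >= 300000 nM, which is a limit. Compound 3 (`O=[N+]([O-])c1ccc(S(=O)(=O)Nc2ccc3nccnc3c2)cc1`) also reads only a limit, >= 300000 nM, so it has no exact value. Compound 4 (`O=S(=O)(Nc1ccc2nccnc2c1)c1ccc(Cl)cc1`) differs from it by chloro in place of nitro on an aromatic carbon, with chloro in place of nitro on an aromatic carbon, para to a large group. The nearest measured change is an at least 7.2-fold higher number from compound 1 to compound 2 (0.86 log units; beyond the scatter), at least modest and beyond the scatter, but it swaps nitro for hydrogen on another core and ends at the limit of >= 300000 nM in this assay, at which 2 of the 3 values shown sit. That step gives no direct measure for chloro, so only a small change is expected, an at least 1.2-fold lower number from compound 3 to compound 4 (0.07 log units; that floor lies within the scatter), with none beyond the scatter. Compound 4 is estimated at 250000 nM, within an expected range of 80000 nM to 300000 nM.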

Compound 4, half-maximal cytotoxic concentration: 23800 nM
Compound 4: middle estimate off by 11-fold (1.02 log units), on the high side, outside the stated range (below it).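

Chloro in place of nitro on this aromatic carbon gave an at least 12-fold lower number from compound 3 to compound 4 (1.10 log units; beyond the scatter), so the change moves the number downward on this core, whereas removing nitro from the core of compound 1 gave an at least 7.2-fold higher number from compound 1 to compound 2 (0.86 log units; beyond the scatter). A nitro group is therefore not required for a low number in this assay. As far as these compounds go, compound 3 reads >= 300000 nM, which is a limit, so the full size of the step remains unknown: the limit of >= 300000 nM in this assay, at which 2 of the 4 values shown sit.

From the compounds shown here alone, what an amine or a methoxy group would give at this place remains open. So does whether chloro has the same effect on the core of compound 1.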